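Cytotoxicity notes: removing a methoxy group from compound 2

The compounds below may be only part of what the source reports. "The series", "measured", "known", "first", "only" and "open" are said of these compounds alone.

Three compounds have been run in an ADME assay on THLE-2 cells (Homo sapiens) for cytotoxicity, read by MTT assay; a higher number here means that more compound is tolerated, a lower number that less compound is tolerated. Compound 1 `O=C(C=CNc1cc(-c2ccccc2)nn1-c1ccccc1)c1cccs1` gives 19900 nM. Compound 3 `Fc1ccc(-c2ccnc3c2c(-c2ccccc2)nn3-c2ccccc2)cc1` gives 19700 nM. Compound 2 `COc1ccc(-c2nc3c(c(-c4ccccc4)nn3-c3ccccc3)c(-c3ccc(N4CCN(C)CC4)cc3)c2C#N)cc1` gives 37500 nM, the highest of the three numbers, yet the gaps to compound 1 and to compound 3 both stay within the scatter, so none of the three can be told apart on how much is tolerated. Going by the values given here, no pair of measured compounds differs in a single place, so no single-step effect is known for this series.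

Compound 4 `CN1CCN(c2ccc(-c3c(C#N)c(-c4ccccc4)nc4c3c(-c3ccccc3)nn4-c3ccccc3)cc2)CC1` has not been measured. It differs from compound 2 in one place: hydrogen in place of methoxy on an aromatic carbon. The change is small in what is counted, and the three measured values sit close together despite their wide structural spread, which gives no ground to expect a movement beyond the scatter in this assay in either direction. The step from compound 2 to compound 4 is therefore estimated at a 1.1-fold lower number from compound 2 to compound 4 (0.03 log units; within the scatter), essentially flat. For compound 4 the expected value in this assay is 35000 nM, with a range from 15000 nM to 80000 nM; the range is kept wide since nothing in the series ties this change to a known step.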

Compound 4, half-maximal cytotoxic concentration: 15100 nM
Compound 4: the middle estimate sits 2.3-fold (0.37 log units) above what was measured; measured number inside the range.
By their numbers in this assay, from the lowest: compounds 4, 3, 1 and 2 (each within the scatter of the next, the first and the last beyond it).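

Going by these compounds alone, this is the first single-place step: in this assay, hydrogen in place of methoxy on an aromatic carbon, para to a large group, shows a 2.5-fold lower number from compound 2 to compound 4 (0.40 log units; beyond the scatter) and so marks this position as one where the 4-methoxyphenyl to phenyl change is not silent. Within the data shown here, the step is modest and rests on a single pair, but it shows that less compound is tolerated without the methoxy and that losing only two heavy atoms can carry the number past the scatter, something the earlier compounds, with no pair differing in one place, could not show. Nothing measured here bears on the reason for this step.

As far as these compounds go, whether this is specific to methoxy or would follow from other groups at this position stays open, and a fluorine, a hydroxyl or a dimethylamino group on the same carbon would help separate these readings. Also open is whether the same step would appear on a core without the nitrile, as the compounds shown offer no such pair.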